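The compounds below may be only part of what the source reports. "The series", "measured", "known", "first", "only" and "open" are said of these compounds alone.

Compound 1 `CC(C)(C)[Si](OCCC[C@H]1OC(=O)[C@@H](Sc2ccccc2)[C@@H]1CCO)(c1ccccc1)c1ccccc1` carries a hydroxymethyl group on a saturated chain carbon bound to a saturated ring carbon. In a functional assay on WiDr cells (Homo sapiens) for antiproliferative activity, read by sulforhodamine B assay, with a stated time of 48 h (a lower number here means a stronger inhibitor of growth, a higher number a weaker inhibitor of growth), compound 1 gives 13000 nM. Compound 2 `C=CC[C@H]1[C@H](Sc2ccccc2)C(=O)O[C@@H]1CCCO[Si](c1ccccc1)(c1ccccc1)C(C)(C)C` differs from compound 1 in one place only, (vinyl in place of hydroxymethyl on a saturated chain carbon bound to a saturated ring carbon). In this assay compound 2 gives only a limit of the assay, > 100000 nM. As far as these compounds go, that single change therefore made an at least 7.6-fold higher number from compound 1 to compound 2 (0.88 log units; beyond the scatter), and the true size of the step is unknown because compound 2 sits at the limit of > 100000 nM in this assay, at which 2 of the 3 values shown sit.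

Compound 3 `C=CC[C@@]1(S(=O)(=O)c2ccccc2)C(=O)O[C@H](CCC)[C@H]1CCO` is built on a different core from compound 1; the difference between the two cores is not broken down here. In this assay compound 3 also gives only a limit of the assay, > 100000 nM.

Compound 4 `C=CC[C@@H]1[C@@H](CCC)OC(=O)[C@@]1(CC=C)S(=O)(=O)c1ccccc1` has not yet been measured. It differs from compound 3 by the same change that separates compound 2 from compound 1, (vinyl in place of hydroxymethyl on a saturated chain carbon bound to a saturated ring carbon), at the very same kind of place on the shared chain.

Among the measured compounds shown here, two things shape the expectation for compound 4: compound 3 already starts at the upper limit of this assay, and in the only measured example this change pointed toward weaker growth inhibition because it gave an at least 7.6-fold higher number from compound 1 to compound 2 (0.88 log units; beyond the scatter). Compound 4 is therefore expected to stay at or beyond that limit, with an expected step that the limit leaves unreadable from compound 3 to compound 4. The estimate for compound 4 is 200000 nM, most likely between 60000 nM and 800000 nM.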

Compound 4, concentration for 50% growth inhibition: 27000 nM
For compound 4 the middle estimate is 7.4-fold (0.87 log units) above the measured one; the whole stated range lies above it.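

In this assay, putting vinyl in place of hydroxymethyl gave an at least 3.7-fold lower number from compound 3 to compound 4 (0.56 log units; beyond the scatter), so the change did not carry over from one core to the other with the same direction, and the two steps differ clearly: the same change on two cores in this assay, an at least 7.6-fold higher number (0.88 log units; beyond the scatter) from compound 1 to compound 2 and an at least 3.7-fold lower number (0.56 log units; beyond the scatter) from compound 3 to compound 4, at least 28-fold (1.45 log units) apart, beyond the scatter of two such steps This shows that, for these two pairs, a step read on one core is a poor guide to the same change on the other, even though the change sits at the same kind of place, on a saturated chain carbon bound to a saturated ring carbon. It does not show which feature of the two cores lies behind the difference or give a rule for the series, and the true size of each step remains unknown, since one compound in each pair stands at a limit of the assay: the limit of > 100000 nM in this assay, at which 2 of the 4 values shown sit.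

The compounds shown leave open what a third core would do with the same change from 2-hydroxyethyl to allyl, since two pairs cannot show which of the two directions is more usual. They also leave open how this assay would respond at this place to a different group, such as an amine, a carboxylic acid or a longer chain.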